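Ureido in place of chloro on the terminal aryl urea

This account rests on a few compounds, and the source may have more. Where it says the series, first, only, none or still open, it means among the compounds named here.

Compound 1, `COc1ccc(NC(=O)Nc2cccc(-c3nc(-c4ccc(NC(=O)c5cccnc5)cc4Cl)no3)c2)cc1`, gives 3000 nM in a functional assay on MDA-MB-231 cells (Homo sapiens) for antiproliferative activity, read by MTT assay, with a stated time of 72 h; on this read-out lower numbers stand for stronger inhibition and higher numbers for weaker inhibition.
Compound 2, `O=C(Nc1cccc(-c2nc(-c3ccc(NC(=O)c4cccnc4)cc3Cl)no2)c1)Nc1ccc(Cl)c(C(F)(F)F)c1`, gives 1900 nM in this assay.
Compound 3, `CC(=O)Nc1ccc(NC(=O)Nc2cccc(-c3nc(-c4ccc(NC(=O)c5cccnc5)cc4Cl)no3)c2)cc1Br`, gives 1000 nM in this assay.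

Compound 2 stands second highest of the three numbers; its distances to compound 1 and to compound 3 are both within the scatter. Compound 4, `NC(=O)Nc1ccc(NC(=O)Nc2cccc(-c3nc(-c4ccc(NC(=O)c5cccnc5)cc4Cl)no3)c2)cc1C(F)(F)F`, differs from compound 2 by ureido in place of chloro on an aromatic carbon. Going by the values given here, the steps that bear on this are a 1.6-fold lower number from compound 1 to compound 2 (0.20 log units; within the scatter), a 1.9-fold lower number from compound 2 to compound 3 (0.28 log units; within the scatter) and a 3.0-fold lower number from compound 1 to compound 3 (0.48 log units; beyond the scatter); all changes at this terminal aryl group were small, and compound 3, which also carries an amide-type nitrogen there, gave the lowest number. A small step downward is therefore expected, a 1.6-fold lower number from compound 2 to compound 4 (0.20 log units; within the scatter), though it may well stay within the scatter. Compound 4 is estimated at 1200 nM, in the range 500 nM to 3000 nM.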

Compound 4, half-maximal inhibitory concentration: 3400 nM
For compound 4 the middle estimate is 2.8-fold (0.45 log units) below the measured one; measured number outside the range, above it.
By their numbers in this assay, from the lowest: compounds 3, 2, 1 and 4 (each within the scatter of the next, the first and the last beyond it).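

Putting ureido in place of chloro, on an aromatic carbon ortho to a trifluoromethyl group, gives a 1.8-fold higher number from compound 2 to compound 4 (0.25 log units; within the scatter) in this assay. Going by these compounds alone, the change adds hydrogen-bond donors and an acceptor that chloro lacks, yet the number stays within the scatter of the one for the chloro compound. Nothing shown here offers a reason for this outcome.

As far as these compounds go, it remains open whether an amine or a carboxylic acid on this same carbon would also stay within the scatter. From the compounds shown here alone, it is equally open whether ureido would give a similar number without the neighbouring trifluoromethyl group.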